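The compounds below may be only part of what the source reports. "The series", "measured", "known", "first", "only" and "open" are said of these compounds alone.

Compound 1 `Cc1cc(-c2ccccc2)cn2c(CSCCc3ccccc3)cnc12` is the parent of the series; in an ADME assay on HEL cells (Homo sapiens) for cytotoxicity, with a stated time of 3 days (a lower number here means that less compound is tolerated, a higher number that more compound is tolerated), compound 1 gives 20 ug/mL. Compound 2 `Cc1cc(-c2ccc(O)cc2)cn2c(CSCCc3ccccc3)cnc12` carries hydroxy in place of hydrogen on an aromatic carbon; in this assay compound 2 reaches only the limit >= 100 ug/mL. Compound 3 `Cc1cc(-c2cccc([N+](=O)[O-])c2)cn2c(CSCCc3ccccc3)cnc12` carries nitro in place of hydrogen on an aromatic carbon; in this assay compound 3 likewise stops at the limit >= 100 ug/mL. The steps of an at least 5.0-fold higher number from compound 1 to compound 2 (0.69 log units; beyond the scatter) and an at least 5.0-fold higher number from compound 1 to compound 3 (0.69 log units; beyond the scatter) are both at least modest, while the step that the two limits leave unreadable from compound 2 to compound 3 cannot be read because of the limit of >= 100 ug/mL in this assay, at which 2 of the 3 values shown sit. Compound 4 `Cc1cc(I)cn2c(CSCCc3ccccc3)cnc12` differs from compound 3 by iodo in place of 3-nitrophenyl on an aromatic carbon. For the measured compounds named here, no measured step removes the 3-nitrophenyl, so the two steps from compound 1 give only the scale of change seen so far. Compound 4 is expected near 50 ug/mL, between 15 ug/mL and 100 ug/mL, an expected step of an at least 2.0-fold lower number from compound 3 to compound 4 (0.30 log units; that floor lies within the scatter).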

Compound 4, minimum cytotoxic concentration: >= 0.8 ug/mL
Compound 4: a limit, no number; the forecaster's own chance of this, stated with the estimate: 40%; the middle value lies beyond the limit too.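

In this assay compound 4 gives only a limit, >= 0.8 ug/mL, and none of its steps from compound 1, compound 2 or compound 3 can be read. As far as these compounds go, whether iodo in place of phenyl raises or lowers the number remains open.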